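A few compounds are considered here, and "the series" means these few. Any claim that something is new, unique, unknown or untested is made for them only; others in the source may bear on it.

The compounds share one core, seen in compound 1 `CC1=C(/C=C/C(=O)/C=C/c2ccccc2C(F)(F)F)C(C)(C)CCC1O`, with a phenyl group at one end carrying fluorine or trifluoromethyl. In a functional assay on CWR22R cells (Homo sapiens) for cytotoxicity, read by MTT assay, with a stated time of 72 h (a higher number here means a weaker inhibitor, a lower number a stronger inhibitor), compound 1 gives 2300 nM. Compound 2 `CC1=C(/C=C/C(=O)/C=C/c2ccccc2F)C(C)(C)CCC1O` gives 3300 nM in this assay, and compound 3 `CC1=C(/C=C/C(=O)/C=C/c2cc(C(F)(F)F)ccc2F)C(C)(C)CCC1O` gives 2000 nM. One measured step gave a 1.4-fold higher number from compound 1 to compound 2 (0.16 log units; within the scatter) and the other 1.7-fold lower number from compound 2 to compound 3 (0.22 log units; within the scatter), so compound 2 sits within the scatter of both of its neighbours. Compound 4 `CC1=C(/C=C/C(=O)/C=C/c2cccc(C)c2)C(C)(C)CCC1O` alters the phenyl group: 3-methylphenyl in place of 2-fluorophenyl on a double-bonded chain carbon bound to a double-bonded chain carbon. For the measured compounds named here, no measured step trades fluorine for methyl, yet every change on that ring so far stayed within the scatter, so the expected step is a 1.1-fold lower number from compound 2 to compound 4 (0.04 log units; within the scatter). Compound 4 is therefore estimated at 3000 nM, with a likely range from 1500 nM to 6000 nM.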

Compound 4, half-maximal inhibitory concentration: 4400 nM
Compound 4: the middle estimate sits 1.5-fold (0.17 log units) below what was measured; low and high end bracket the measured number.
By their numbers in this assay, from the lowest: compounds 3, 1, 2 and 4 (each within the scatter of the next, the first and the last beyond it).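

Exchanging 2-fluorophenyl for 3-methylphenyl gives a 1.3-fold higher number from compound 2 to compound 4 (0.12 log units; within the scatter) in this assay. For the compounds shown here, compound 4 is the first compound here whose phenyl group carries neither fluorine nor trifluoromethyl, yet its number stays within the scatter of that of compound 2, so at this place on the shared core, fluorine is not needed to keep the number in that range. From the compounds shown here alone, whether an amine or a carboxylic acid on this phenyl group would do the same remains open. No evidence is available here to explain why these numbers stay so close.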